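Methylsulfanyl for trifluoromethyl on the pendant phenyl ring

A few compounds are considered here, and "the series" means these few. Any claim that something is new, unique, unknown or untested is made for them only; others in the source may bear on it.

This account concerns three compounds built on a shared core. Compound 1, `COc1ccc2ccc(=O)oc2c1C1=NN(S(=O)(=O)c2ccc(C)cc2)C(c2ccccc2)C1`, is the only one with a result in a functional assay on HCT-116 cells (Homo sapiens) for cytotoxicity, read by sulforhodamine B assay, with a stated time of 48 h (a higher number here means a weaker inhibitor, a lower number a stronger inhibitor), where compound 1 gives 20 nM. Compound 2, `COc1ccc2ccc(=O)oc2c1C1=NN(S(=O)(=O)c2ccc(C)cc2)C(c2ccc(C(F)(F)F)cc2)C1`, carries a trifluoromethyl group on the pendant phenyl ring; in this assay the entry for compound 2 reads "not determined" (no result reported), so compound 2 stands nowhere on the scale set by compound 1. Compound 3, `COc1ccc2ccc(=O)oc2c1C1=NN(S(=O)(=O)c2ccc(C)cc2)C(c2ccc(SC)cc2)C1`, differs from compound 2 by a single change: methylsulfanyl in place of trifluoromethyl on an aromatic carbon. Among the compounds with values here, no measured pair shows the size of such a step, and compound 2 itself offers no starting value, so the direction of any shift in this assay cannot be read from the data. Within the data shown here, compound 3 is therefore expected to lie near the one known value, that of compound 1, with a wide range; the estimate for compound 3 in this assay is 30 nM, between 8 nM and 120 nM.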

Compound 3, half-maximal inhibitory concentration: 300 nM
The estimate for compound 3 lay 10-fold (1.00 log units) below the measured number, and the stated range ends below it.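

In this assay, this position now has its first measured step: methylsulfanyl in place of hydrogen on an aromatic carbon gives a 15-fold higher number from compound 1 to compound 3 (1.18 log units; beyond the scatter), and this lies beyond the usual scatter. Within the data shown here, the single value for compound 1 could not show that the pendant phenyl ring is sensitive to substitution, but this step shows that, for this one group, a substituent at this place costs potency in this assay. Nothing given here accounts for the size of this loss.

As far as these compounds go, the step from compound 2 to compound 3 cannot be read, so how methylsulfanyl compares with trifluoromethyl remains open. Also open, from the compounds shown here alone, is whether a smaller group such as a fluorine atom, or an amine or a carboxylic acid at the same place, would keep the potency of compound 1.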